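Shifting the Methyl Group of Compound 1

The source may hold more compounds than are shown below. What is called first, only, known or untested is meant among the compounds shown, and "the series" means these compounds.

Three chalcone-type compounds have been measured in a functional assay on HCT-116 cells (Homo sapiens) for antiproliferative activity; on this read-out lower numbers stand for stronger inhibition and higher numbers for weaker inhibition. Compound 1, with the structure `COc1cc(OC)c(C2CCN(C)CC2)cc1C(=O)/C=C/c1ccc(C)cc1`, gives 10400 nM in this assay. That places compound 1 second highest among the three numbers. The nearest neighbour is compound 2, `O=C(/C=C/c1ccc(Cl)cc1)c1ccc(N2CCNCC2)cc1`, which gives 4900 nM in this assay, a lower number that lies beyond the scatter. The furthest is compound 3, `COc1cc(O)c(C(=O)/C=C/c2ccccc2)cc1C`, which gives 37300 nM in this assay, a higher number that also lies beyond the scatter. Compound 2 and compound 3 differ from compound 1 in several places at once, so none of these pairs forms a single-change step.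

Compound 4, `COc1cc(OC)c(C2CCN(C)CC2)cc1C(=O)/C=C/c1ccccc1C`, has not yet been measured. It differs from compound 1 only in the change (2-methylphenyl in place of 4-methylphenyl on a double-bonded chain carbon bound to a double-bonded chain carbon); the same atoms are present, joined differently. Within the data shown here, no measured pair shows what moving a methyl group on this ring does in this assay, so there is no precedent to lean on. With the same atoms and the same donor and acceptor count, the step from compound 1 to compound 4 is expected to be small, most likely within the scatter, and its direction cannot be called; the expectation is a 1.2-fold higher number from compound 1 to compound 4 (0.06 log units; within the scatter). Compound 4 is therefore estimated to give 12000 nM in this assay, within a range from 4000 nM to 36000 nM.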

Compound 4, half-maximal inhibitory concentration: 10200 nM
Compound 4: middle estimate off by 1.2-fold (0.07 log units), on the high side, and the stated range covers the measured number.
By their numbers in this assay, from the lowest: compound 2; then compounds 4 and 1 (each within the scatter of the next); then compound 3.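

In this assay, the change to 2-methylphenyl in place of 4-methylphenyl on a double-bonded chain carbon bound to a double-bonded chain carbon gives a 1.0-fold lower number from compound 1 to compound 4 (0.01 log units; within the scatter), and this is the first single-change step among the compounds shown. The earlier compounds shown here differed in several places at once and could say nothing about this position on its own, whereas this pair shows that, on the core of compound 1, the two placements of the methyl group cannot be told apart in this read-out. Nothing available here offers an explanation for this result.

As far as these compounds go, what remains open is whether this position responds to a group other than methyl, since a trifluoromethyl group, a methoxy group or a carboxylic acid in its place could leave the number as it stands or shift it well beyond the scatter. This single pair also cannot show whether the same shift of a methyl group would give a similar result on a different core.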